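Swapping ethoxy for fluoro on the aryl ether

A few compounds are considered here, and "the series" means these few. Any claim that something is new, unique, unknown or untested is made for them only; others in the source may bear on it.

Of the compounds shown here, three built on one shared core have been tested in a functional assay on CHO cells for agonist activity at Free fatty acid receptor 1 (Homo sapiens), read by FLIPR, tested at 100 nM; on this read-out lower numbers stand for a weaker effect and higher numbers for a stronger effect at the one concentration tested. Compound 1 `O=C(O)COc1ccc(NC(=O)c2ccccc2)cc1F` gives 3.56%. Compound 2 `CC(Oc1ccccc1)C(=O)Nc1ccc(OCC(=O)O)c(F)c1` gives 35.7%, and compound 3 `CCOc1ccccc1OC(C)C(=O)Nc1ccc(OCC(=O)O)c(F)c1` gives 8.79%. On these numbers compound 3 stands second highest of the three: its nearest neighbour is compound 1, whose value lies within the scatter of its own, while compound 2 lies beyond the scatter, above it. For the measured compounds named here, the single one-place step among the measured compounds is a number 26.9 percentage points lower from compound 2 to compound 3 (beyond the scatter), an ethoxy in place of hydrogen on an aromatic carbon, and it is modest in size.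

Compound 4 `CC(Oc1ccccc1F)C(=O)Nc1ccc(OCC(=O)O)c(F)c1` has not been measured. It differs from compound 3 by fluoro in place of ethoxy on an aromatic carbon, which read one bond further out is 2-ethoxyphenyl to 2-fluorophenyl. Going by the values given here, only one measured step bears on it, a number 26.9 percentage points lower from compound 2 to compound 3 (beyond the scatter), since removing the ethoxy brings the structure back toward compound 2. Fluoro is not hydrogen, however, and no measured step tells how closely it follows. The expected outcome is a rise in this assay that recovers part of that step. Compound 4 is therefore expected to give 22%, within a range from 6% to 42%. That estimate means a step of a number 13.2 percentage points higher from compound 3 to compound 4 (beyond the scatter).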

Compound 4, a percentage reported as activity, at one concentration (the size of the read-out at that concentration, not a potency): 35.1%
Compound 4: the middle estimate sits 13.1 percentage points below what was measured; the range from low to high includes it.
By their numbers in this assay, from the lowest: compounds 1 and 3 (each within the scatter of the next); then compounds 4 and 2 (each within the scatter of the next).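

Fluoro in place of ethoxy on this aromatic carbon, ortho to a large group, gives a number 26.3 percentage points higher from compound 3 to compound 4 (beyond the scatter) in this assay and so shows that the low number of compound 3 goes with ethoxy itself, not with simply having a group at this carbon. Fluoro in place of hydrogen gives a number 0.6 percentage points lower from compound 2 to compound 4 (within the scatter) and thus, among compounds 2, 3 and 4, hydrogen and fluoro read alike while ethoxy alone stands apart. Nothing available explains why these groups behave this way.

For the compounds shown here, with only three groups at this carbon, it remains open which part of ethoxy goes with the lower number, and methoxy, methyl or chloro there could begin to separate its oxygen from its chain. Each number also comes from a single concentration, so the similar readings of compound 2 and compound 4 do not establish equal potency.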